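Propyl sulfide series: changing the nitrogen substituent

A few compounds are considered here, and "the series" means these few. Any claim that something is new, unique, unknown or untested is made for them only; others in the source may bear on it.

Measured in a functional assay on a cell-free system (Platelet, plasma, Homo sapiens) for inhibition, with stated times of 1 min and 3 min; on this read-out lower numbers stand for stronger inhibition and higher numbers for weaker inhibition:
compound 1 `CC(C)Sc1nc(NC2CCCCC2)c2ncn([C@@H]3O[C@H](CO)[C@@H](O)[C@H]3O)c2n1` gives 187000 nM
compound 2 `CCCSc1nc(NC2CCCCC2)c2ncn([C@@H]3O[C@H](CO)[C@@H](O)[C@H]3O)c2n1` gives 151000 nM

Compound 2 stands at 151000 nM, within the scatter of compound 1, so the two count as level. Among the measured compounds shown here, the only measured step, a 1.2-fold lower number from compound 1 to compound 2 (0.09 log units; within the scatter), is propyl in place of isopropyl on a sulfur, and it lies within the scatter.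

Compound 3 `CCCSc1nc(NCc2ccc(OC)cc2)c2ncn([C@@H]3O[C@H](CO)[C@@H](O)[C@H]3O)c2n1` keeps the propyl on sulfur of compound 2 and carries 4-methoxybenzyl in place of cyclohexyl on a nitrogen on an aromatic ring. For the measured compounds named here, no measured step touches that nitrogen. The step of a 1.2-fold lower number from compound 1 to compound 2 (0.09 log units; within the scatter) bears on it only indirectly, showing that one change elsewhere on the shared core left this assay within the scatter. The data offer no direction for the new group, so no change beyond the scatter is expected, and the range is kept wide on both sides. The expected step is a 1.3-fold lower number from compound 2 to compound 3 (0.10 log units; within the scatter), with low confidence in its direction. Compound 3 is estimated at 120000 nM, with an expected range from 40000 nM to 350000 nM.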

Compound 3, half-maximal inhibitory concentration: 181000 nM
Compound 3: middle estimate off by 1.5-fold (0.18 log units), on the low side; low and high end bracket the measured number.
By their numbers in this assay, from the lowest: compounds 2, 3 and 1 (each within the scatter of the next).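

In this assay, the change at the nitrogen on an aromatic ring gives a 1.2-fold higher number from compound 2 to compound 3 (0.08 log units; within the scatter), so with the propyl on sulfur held constant, 4-methoxybenzyl and cyclohexyl count as level. Among the compounds shown here, this is the first measured change at that nitrogen, and it swaps one six-membered non-aromatic ring of carbon only for a six-membered aromatic ring of carbon only in a group that also holds 1 hydrogen-bond acceptor, with no shift beyond the scatter. The earlier step on sulfur, a 1.2-fold lower number from compound 1 to compound 2 (0.09 log units; within the scatter), also lies within the scatter, so neither single change has yet moved the read-out, and no supporting data explain this level result.

Open, as far as these compounds go, is whether a group of a different kind on that nitrogen, such as a benzyl carrying a carboxylic acid or a chain ending in an amine, would shift the number beyond the scatter. Also open, from the compounds shown here alone, is whether a longer chain on sulfur, such as hexyl, would do so with either nitrogen substituent.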